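The compounds below may be only part of what the source reports. "The series", "measured", "known", "first", "only" and "open" are said of these compounds alone.

Working notes on the series. Three compounds have numbers in an assay on HEK293 cells for displacement of a labelled ligand from Melanocortin receptor 4 (Homo sapiens); on this read-out higher numbers stand for weaker inhibition and lower numbers for stronger inhibition. Compound 1 `CC(C)C[C@H](N)c1cc(C(F)(F)F)ccc1N1CCN(C(=O)COc2ccc([N+](=O)[O-])cc2)CC1` gives 3100 nM and compound 2 `CC(C)C[C@H](N)c1cc(C(F)(F)F)ccc1N1CCN(C(=O)CNc2ccccc2)CC1` gives 3600 nM; the step of a 1.2-fold higher number from compound 1 to compound 2 (0.06 log units; within the scatter) lies within the scatter. Compound 3 `Cc1cc(Cl)ccc1CC(C)C(=O)N1CCN(c2ccc(C(F)(F)F)cc2[C@@H](N)CC(C)C)CC1` gives 38 nM, the lowest of the three numbers, and stands clearly apart from both, with an 82-fold lower number from compound 1 to compound 3 (1.91 log units; beyond the scatter) and a 95-fold lower number from compound 2 to compound 3 (1.98 log units; beyond the scatter). Both of these steps exchange the entire group on the carbonyl carbon, so they show how strongly that part of the molecule can move the number, but neither of them touches only the aromatic ring within that group.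

Compound 4 `Cc1ccc(CC(C)C(=O)N2CCN(c3ccc(C(F)(F)F)cc3[C@@H](N)CC(C)C)CC2)cc1C` differs from compound 3 in exactly such a way: 3,4-dimethylphenyl in place of 4-chloro-2-methylphenyl on a saturated chain carbon, two bonds along the chain from a carbonyl carbon. For the measured compounds named here, no measured step addresses an exchange of this kind, so the guidance is indirect: compound 3 with its 1-(4-chloro-2-methylbenzyl)ethyl group sits far ahead of compounds 1 and 2, and compound 4 keeps the same chain with only the aromatic ring exchanged. A modest step is therefore expected, with some risk of a weaker number rather than a stronger one. For compound 4 the estimate in this assay is 65 nM, within 20 nM to 220 nM. This estimate corresponds to an expected 1.7-fold higher number from compound 3 to compound 4 (0.23 log units; within the scatter) in this assay.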

Compound 4, inhibition constant: 240 nM
Compound 4: the middle estimate sits 3.7-fold (0.57 log units) below what was measured, outside the stated range (above it).
By their numbers in this assay, from the lowest: compound 3; then compound 4; then compounds 1 and 2 (each within the scatter of the next).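

The ring on this chain is not interchangeable: in this assay, 3,4-dimethylphenyl in place of 4-chloro-2-methylphenyl gives a step beyond the scatter (a 6.3-fold higher number from compound 3 to compound 4 (0.80 log units; beyond the scatter)), although both groups hold 8 heavy atoms and one six-membered aromatic ring of carbon only. For the compounds shown here, this is the first step that leaves the chain in place and exchanges only the ring, on a saturated chain carbon, two bonds along the chain from a carbonyl carbon. The 1-(3,4-dimethylbenzyl)ethyl group still stands clearly apart from the other two groups on the carbonyl carbon (a 15-fold lower number from compound 2 to compound 4 (1.18 log units; beyond the scatter); a 13-fold lower number from compound 1 to compound 4 (1.11 log units; beyond the scatter)), so a large part of the separation survives this ring exchange, and no data on hand bear on the reason for the step.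

This exchange removes the chlorine and alters the methyl pattern in one step, so the compounds shown cannot assign the step to either change. A 2,4-dimethylphenyl group would separate the two, and a 4-chloro-3-methylphenyl group would show whether the chlorine keeps its value with the methyl placed as in compound 4.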